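The compounds below may be only part of what the source reports. "The series", "measured", "known", "first", "only" and "open" are said of these compounds alone.

Compound 1 `CCc1cccn1S(=O)(=O)c1ccc(C)cc1` holds the lower of the two measured numbers in an assay on isolated protein for antagonist activity at Rap guanine nucleotide exchange factor 4 (Homo sapiens), read by fluorescence and cAMP accumulation (on this read-out higher numbers stand for weaker inhibition and lower numbers for stronger inhibition), where compound 1 gives 4000 nM. Compound 2 `CCc1cccn1S(=O)(=O)c1ccc(OC)cc1` carries a methoxy in place of the methyl on an aromatic carbon, and in this assay compound 2 gives 8000 nM, a move of a 2.0-fold higher number from compound 1 to compound 2 (0.30 log units; within the scatter). Compound 3 `CCc1cccn1S(=O)(=O)c1ccc(C(F)(F)F)cc1` carries a trifluoromethyl at that carbon, and in this assay compound 3 shows only a limit, > 300000 nM. That gives an at least 75-fold higher number from compound 1 to compound 3 (1.87 log units; beyond the scatter) and an at least 37-fold higher number from compound 2 to compound 3 (1.57 log units; beyond the scatter). Compound 4 `CCc1cccn1S(=O)(=O)c1ccc(C)cc1C` is reached from compound 1 by methyl in place of hydrogen on an aromatic carbon. Among the measured compounds shown here, no measured step adds a group at a second carbon; all three exchange the group already present, so none bears directly on it. Compound 4 is therefore expected to lie near compound 1, an estimated 1.3-fold higher number from compound 1 to compound 4 (0.10 log units; within the scatter), at 5000 nM with a range of 1500 nM to 20000 nM.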

Compound 4, half-maximal inhibitory concentration: 1300 nM
For compound 4 the middle estimate is 3.8-fold (0.59 log units) above the measured one; measured number below the stated range.
By their numbers in this assay, from the lowest: compound 4; then compounds 1 and 2 (each within the scatter of the next). At a limit, above all of these: compound 3.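

Methyl in place of hydrogen at this aromatic carbon, ortho to a large group and meta to a methyl group, gives a 3.1-fold lower number from compound 1 to compound 4 (0.49 log units; beyond the scatter) in this assay. Among the compounds shown here, every earlier step exchanged the group already present, and none of them gave a lower number beyond the scatter, so this is the first sign that a second carbon of the ring can take a group and lower the number, which here stands for stronger inhibition. Nothing shown here accounts for this step.

The compounds shown leave open whether an ethyl, a chlorine or an amine at this carbon would move the number the same way. They also leave open whether the step holds with methoxy in place of the existing methyl.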